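A few compounds are considered here, and "the series" means these few. Any claim that something is new, unique, unknown or untested is made for them only; others in the source may bear on it.

Measured compounds and their values:

Compound 1, `N#CC1=C(N)N(c2ccc(S(N)(=O)=O)cc2)C2=C(C(=O)CCC2)C1/C=C/c1ccccc1`, gives 2%.
Compound 2, `COc1ccc(C2C(C#N)=C(N)N(c3ccc(S(N)(=O)=O)cc3)C3=C2C(=O)CCC3)cc1`, gives 30%.
Compound 3, `COc1cc(CC2C(C#N)=C(N)N(c3ccc(S(N)(=O)=O)cc3)C3=C2C(=O)CCC3)ccc1O`, gives 0%.

All three numbers come from a functional assay on Ehrlich cells (Mus musculus) for antiproliferative activity, read by trypan blue exclusion, with a stated time of 2 h, tested at 10 ug/mL; a higher number here means a stronger effect of the compound at the concentration tested, a lower number a weaker effect. Compound 3 has the lowest of the three readings, but its nearest neighbour, compound 1, lies within the usual scatter of it, so the two cannot be told apart; only compound 2 stands clearly apart, a number 30 percentage points lower from compound 2 to compound 3 (beyond the scatter).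

Compound 4, `COc1ccc(C2C(C#N)=C(N)N(c3ccc(S(N)(=O)=O)cc3)C3=C2C(=O)CCC3)c2ccccc12`, carries a different group on the same saturated ring carbon: 4-methoxynaphthalen-1-yl in place of 4-hydroxy-3-methoxybenzyl on a saturated ring carbon. For the measured compounds named here, two measured steps bear on this. The step of a number 2 percentage points lower from compound 1 to compound 3 (within the scatter) shows that replacing one group by the 4-hydroxy-3-methoxybenzyl changed nothing beyond the scatter, while a number 30 percentage points lower from compound 2 to compound 3 (beyond the scatter) shows that the 4-methoxyphenyl at this position gave a modestly higher reading. Since the entering 4-methoxynaphthalen-1-yl, like the 4-methoxyphenyl of compound 2, is an aromatic ring attached directly to the saturated carbon and bears a methoxy group, a modest rise is expected rather than no change.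

Compound 4 is therefore estimated at 25%, with a range from 5% to 50%, which means an expected step of a number 25 percentage points higher from compound 3 to compound 4 (beyond the scatter).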

Compound 4, a percentage reported as activity, at one concentration (the size of the read-out at that concentration, not a potency): 10%
Beside the measured number, compound 4's estimate is 15 percentage points above it; the range from low to high includes it.
By their numbers in this assay, from the lowest: compounds 3, 1 and 4 (each within the scatter of the next); then compound 2.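

Having a methoxy-bearing aromatic ring attached directly to the saturated ring carbon is not enough to give a clear reading in this assay, as a number 20 percentage points lower from compound 2 to compound 4 (beyond the scatter) when a second six-membered aromatic ring is present in the entering group. The 4-methoxynaphthalen-1-yl group cannot be told apart from the other two groups, with a number 10 percentage points higher from compound 3 to compound 4 (within the scatter) and a number 8 percentage points higher from compound 1 to compound 4 (within the scatter), so compound 2 alone stands clear of the rest among these four compounds. No measured information is available to explain this difference.

The share of the methoxy group in the reading of compound 2 stays open, since a plain phenyl group at this carbon is not among the compounds shown. Also open, from the compounds shown here alone, is how an amine or a carboxylic acid at the same carbon would read.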